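A few compounds are considered here, and "the series" means these few. Any claim that something is new, unique, unknown or untested is made for them only; others in the source may bear on it.

Of the compounds shown here, three sharing one core have been measured in a functional assay on NCI-H460 cells (Homo sapiens) for inhibition, read by sulforhodamine B assay, with a stated time of 48 h; on this read-out lower numbers stand for stronger inhibition of growth and higher numbers for weaker inhibition of growth. Compound 1 `C=C(C)[C@@H]1CC=C(Cn2cc(COc3ccc(C4NC(=O)NC(C)=C4C(=O)OCC)cc3)nn2)CC1` reaches only the limit of the assay, giving > 100000 nM. Compound 2 `C=C(C)[C@@H]1CC=C(Cn2cc(COc3cccc(C4NC(=O)NC(C)=C4C(=O)OCC)c3)nn2)CC1` likewise reaches only a limit, with > 100000 nM. Compound 3 `C=C(C)[C@@H]1CC=C(Cn2cc(COc3cc(C4NC(=O)NC(C)=C4C(=O)OCC)ccc3OC)nn2)CC1`, which carries a methoxy in place of hydrogen on an aromatic carbon, also stops at a limit, at > 100000 nM. Compound 2 thus stands at the limit, as do the two other values shown (the limit of > 100000 nM in this assay, at which 3 of the 3 values shown sit). Within the data shown here, the step from compound 2 to compound 3 is a step that the two limits leave unreadable from compound 2 to compound 3, and no measured step gives a readable size. Compound 4 `C=C(C)[C@@H]1CC=C(Cn2cc(COc3cccc(C4NC(=O)NC(C)=C4C(C)=O)c3)nn2)CC1` differs from compound 2 by methyl in place of ethoxy on a carbonyl carbon, ethoxycarbonyl to acetyl. Among the measured compounds shown here, no measured step bears on this change, and all three values shown sit at the limit; no direction beyond the scatter can be read. Compound 4 is expected to sit near the limit as well, with an estimated step that the limit leaves unreadable from compound 2 to compound 4. The estimate for compound 4 in this assay is 150000 nM, between 40000 nM and 500000 nM.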

Compound 4, concentration for total growth inhibition: > 100000 nM
Compound 4 gave a limit, no number (the forecaster's own chance of this, stated with the estimate: 80%); the middle value is on the limit's open side.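

Compound 2 and compound 4 both stop at a limit, so swapping ethoxycarbonyl for acetyl gives no readable step, and all the values share one ceiling: the limit of > 100000 nM in this assay, at which 4 of the 4 values shown sit. The compounds shown leave open whether any change to the shared core gives a real number, and how these groups rank.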